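A few compounds are considered here, and "the series" means these few. Any claim that something is new, unique, unknown or untested is made for them only; others in the source may bear on it.

Two compounds with the same core differ only at the ring nitrogen of the piperidine. Compound 1 `CNC(=O)c1ccc2c(c1)nc(-c1cc(C)c(O)c(C)c1)n2CC1CCNCC1` carries a hydrogen there, and in a physicochemical assay for lipophilicity, at pH 7.4 (on this read-out lower numbers stand for lower lipophilicity and higher numbers for higher lipophilicity), compound 1 gives 0.8. Compound 2 `CNC(=O)c1ccc2c(c1)nc(-c1cc(C)c(O)c(C)c1)n2CC1CCN(C(=O)c2ccccc2)CC1` carries a benzoyl group instead, and in this assay compound 2 gives 3.2. Within the data shown here, the single measured step, a number 2.40 log units higher from compound 1 to compound 2 (beyond the scatter), is large. Among the measured compounds shown here, compound 2 therefore stands highest of the two numbers known so far, with compound 1 the only neighbour, well below it.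

Compound 3 `CNC(=O)c1ccc2c(c1)nc(-c1cc(C)c(O)c(C)c1)n2CC1CCN(C(C)=O)CC1` has not yet been measured. The change from compound 2 is methyl in place of phenyl on a carbonyl carbon, that is, benzoyl to acetyl. For the measured compounds named here, no measured step covers this exact change; the one step known, a number 2.40 log units higher from compound 1 to compound 2 (beyond the scatter), shows only that placing benzoyl on the amine nitrogen of compound 1 raised the number strongly. Since compound 3 keeps the carbonyl but loses the phenyl, a fall in this assay beyond the scatter is expected, though not back to the value of compound 1. The expected step is a number 1.60 log units lower from compound 2 to compound 3 (beyond the scatter). For compound 3 the estimated value in this assay is 1.6, within a range of 1 to 2.2.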

Compound 3, distribution coefficient: 2
Estimate against measurement, compound 3: 0.40 log units below, within the range that was stated.
By their numbers in this assay, from the lowest: compound 1; then compound 3; then compound 2.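

With the carbonyl kept on the ring nitrogen, this assay shows a number 1.20 log units lower from compound 2 to compound 3 (beyond the scatter) when methyl takes the place of phenyl, so the read-out at this position depends on what sits on the carbonyl carbon and not only on the presence of a carbonyl. Acetyl in place of hydrogen on the same nitrogen still gives a number 1.20 log units higher from compound 1 to compound 3 (beyond the scatter) on its own, which divides the rise seen with benzoyl into two parts of equal size: one already present with acetyl, and one that appears only on going from methyl to phenyl. These numbers give the size of each change but not its cause, and no separate evidence bears on this result.

Three compounds cannot show how the number behaves between methyl and phenyl, for example with an ethyl group, a longer chain or a cyclohexyl ring on the carbonyl carbon. Also open, from the compounds shown here alone, is what happens when the carbonyl itself is absent and a benzyl or methyl group sits directly on the ring nitrogen, or when the group on the carbonyl carbon is an amine or carries a carboxylic acid.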